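The source may report more compounds than this note shows. Statements on the series, on what has been measured and on what is new or still open speak of the compounds shown alone.

Compound 1 `COc1cccc(C(=O)Nc2cc(Sc3ncn[nH]3)c(O)c3ccccc23)c1` gives 19.4% in an assay on isolated protein for inhibition of RAC-alpha serine/threonine-protein kinase (Homo sapiens), read by fluorescence, with a stated time of 30 min, tested at 10 uM; on this read-out lower numbers stand for less inhibition and higher numbers for more inhibition at the one concentration tested (going by the name of the read-out).
Compound 2 `COc1ccc(C(=O)Nc2cc(Sc3ncn[nH]3)c(O)c3ccccc23)cc1` gives 30.8% in this assay.
Compound 3 `O=C(Nc1cc(Sc2ncn[nH]2)c(O)c2ccccc12)c1ccc2ccccc2c1` gives 41.6% in this assay.

Compound 3 stands highest of these three numbers: the steps of a number 22.2 percentage points higher from compound 1 to compound 3 (beyond the scatter) and a number 10.8 percentage points higher from compound 2 to compound 3 (beyond the scatter) are both beyond the scatter, as is a number 11.4 percentage points higher from compound 1 to compound 2 (beyond the scatter). Compound 4 `O=C(Nc1cc(Sc2ncn[nH]2)c(O)c2ccccc12)c1ccc([N+](=O)[O-])cc1` differs from compound 3 in one place: 4-nitrophenyl in place of naphthalen-2-yl on a carbonyl carbon. All three measured steps concern the same place, the group on the carbonyl carbon, and the two steps that arrive at naphthalen-2-yl were modest rises. Going back from naphthalen-2-yl to one six-membered aromatic ring of carbon only, now carrying a nitro group, is therefore expected to give a modest fall in this assay, about a number 11.6 percentage points lower from compound 3 to compound 4 (beyond the scatter), though no measured step carries a nitro group. For compound 4 the expected value is 30%, in the range 12% to 50%.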

Compound 4, a percentage reported as inhibition, at one concentration (the size of the read-out at that concentration, not a potency): 37.3%
Compound 4: the middle estimate sits 7.3 percentage points below what was measured; the range from low to high includes it.
By their numbers in this assay, from the lowest: compound 1; then compounds 2, 4 and 3 (each within the scatter of the next, the first and the last beyond it).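

With 4-nitrophenyl in place of naphthalen-2-yl on the carbonyl carbon, the step is a number 4.3 percentage points lower from compound 3 to compound 4 (within the scatter), so one aromatic ring with a nitro group holds the number as well as two rings of carbon only. Nitro in place of methoxy gives a number 6.5 percentage points higher from compound 2 to compound 4 (within the scatter), so these two groups cannot be told apart here. Only the 3-methoxyphenyl compound stays apart, with a number 17.9 percentage points higher from compound 1 to compound 4 (beyond the scatter).

Nothing measured here explains these numbers. From the compounds shown here alone, an amine or a carboxylic acid on this ring remains open, as does an unsubstituted phenyl ring.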